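The compounds below may be only part of what the source reports. "The series", "measured", "known", "first", "only" and "open" are said of these compounds alone.

In an in vitro ADME assay on microsomes from liver (Homo sapiens) for metabolic stability, using NADPH, with a stated time of 10 min, tested at 0.5 uM (on this read-out higher numbers stand for a longer-lived compound and lower numbers for a shorter-lived compound), compound 3 `COc1cc(C2CCN(CC(N)=O)CC2)ccc1Nc1ncc2c(O)cc(-c3ccccc3N(C)S(C)(=O)=O)n2n1` stands at a limit of the assay, < 0.0834 h. Compound 2 `COc1cc(C2CCN(CC(N)=O)CC2)ccc1Nc1ncc2ccc(-c3ccccc3N(C)S(C)(=O)=O)n2n1` likewise sits at a limit, < 0.0834 h. Compound 1 `CNC(=O)CN1CCC(c2ccc(Nc3ncc4ccc(-c5ccccc5OC)n4n3)c(OC)c2)CC1` sits at another limit, < 0.2 h. Two of the three values therefore rest at the limit of < 0.0834 h in this assay, at which 2 of the 3 values shown sit, and one at the limit of < 0.2 h in this assay, at which 1 of the 3 values shown sits. Compound 4 `COc1cc(C2CCN(CC(N)=O)CC2)ccc1Nc1ncc2c(C)cc(-c3ccccc3N(C)S(C)(=O)=O)n2n1` differs from compound 3 by methyl in place of hydroxy on an aromatic carbon. Among the measured compounds shown here, the only measured step, a step that the two limits leave unreadable from compound 2 to compound 3, cannot be read from its two limits, so no measured step gives a size or direction for the change to compound 4. With compound 3 known only through a limit, compound 4 is expected to stay similarly short-lived, an estimated step that the limit leaves unreadable from compound 3 to compound 4. Compound 4 is estimated at 0.06 h, between 0.02 h and 0.2 h.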

Compound 4, half-life: 0.3 h
Estimate against measurement, compound 4: 5.0-fold (0.70 log units) below, outside the stated range (above it).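

Among the compounds shown here, on the aromatic carbon two ring bonds from the ring nitrogen, methyl gives the first readable change in this assay: an at least 3.5-fold higher number from compound 3 to compound 4 (0.55 log units; beyond the scatter). Against hydrogen at the same carbon, methyl gives an at least 3.5-fold higher number from compound 2 to compound 4 (0.55 log units; beyond the scatter), so at this position replacing either hydroxy or hydrogen with methyl brings a measurable gain. The true size of both steps stays open, as compound 2 and compound 3 rest on a limit: the limit of < 0.0834 h in this assay, at which 2 of the 4 values shown sit.

On these data alone, whether ethyl, a longer chain or an amine on this carbon would lengthen the half-life further remains open.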